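From compound 3 to compound 4: one side chain changes

A few compounds are considered here, and "the series" means these few. Any claim that something is new, unique, unknown or untested is made for them only; others in the source may bear on it.

Measured so far in an ADME assay (liver, Mus musculus) for metabolic stability, using microsomes; a lower number here means that the compound disappears faster, a higher number that the compound lasts longer:
- compound 1 `C=CC(=O)Nc1cccc(CNc2nc(Nc3cnoc3)ncc2Cl)c1`: 0.0583 h
- compound 2 `C=CC(=O)Nc1cccc(CNc2nc(Nc3cnn(C4CCOCC4)c3)ncc2Cl)c1`: 0.025 h
- compound 3 `C=CC(=O)Nc1cccc(CNc2nc(Nc3cnn(CC(=O)N4CCOCC4)c3)ncc2Cl)c1`: 0.12 h

Of these three, compound 3 lasts longest, with a half-life of 0.12 h. The next compound, compound 4 `C=CC(=O)Nc1cccc(CNc2nc(Nc3cnn(CCN(C)C)c3)ncc2Cl)c1`, has (dimethylamino)methyl in place of (morpholin-4-yl)carbonyl on a saturated chain carbon bound to an aromatic nitrogen. Among the measured compounds shown here, only one measured step bears on this change, since it also replaces a group on an aromatic nitrogen: a 4.8-fold higher number from compound 2 to compound 3 (0.68 log units; beyond the scatter). That modest step shows that a swap of this kind can move the half-life beyond the usual scatter, but a single step cannot fix the direction of a different swap. Compound 3 is the top value of a small set, so a modest fall in this assay is the more likely outcome, and the expected step is a 2.0-fold lower number from compound 3 to compound 4 (0.30 log units; within the scatter). For compound 4 the estimated half-life is 0.06 h, with an expected range of 0.02 h to 0.16 h.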

Compound 4, half-life: 0.03 h
The estimate for compound 4 lay 2.0-fold (0.30 log units) above the measured number, and the stated range covers the measured number.
By their numbers in this assay, from the lowest: compounds 2, 4 and 1 (each within the scatter of the next, the first and the last beyond it); then compound 3.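

On a saturated chain carbon bound to an aromatic nitrogen, in this assay, putting (dimethylamino)methyl in place of (morpholin-4-yl)carbonyl gives a 4.0-fold lower number from compound 3 to compound 4 (0.60 log units; beyond the scatter) and so removes the longer half-life that compound 3 had reached. The basic-free comparison with the other side chains is flat: 2-(dimethylamino)ethyl in place of oxan-4-yl gives a 1.2-fold higher number from compound 2 to compound 4 (0.08 log units; within the scatter) and the full 1-(2-(dimethylamino)ethyl)-1H-pyrazol-4-yl in place of 1,2-oxazol-4-yl gives a 1.9-fold lower number from compound 1 to compound 4 (0.29 log units; within the scatter) in this same read-out, both within the scatter. Nothing measured here explains the drop from compound 3 to compound 4.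

The compounds shown leave open whether the longer half-life of compound 3 goes with its carbonyl or with its ring. A 2-(morpholin-4-yl)ethyl chain, which keeps the ring without the carbonyl, or a dimethylamide, which keeps the carbonyl without the ring, would separate the two.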